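Replacing the Fluorophenyl Ethenyl Arm with Quinoline

This account rests on a few compounds, and the source may have more. Where it says the series, first, only, none or still open, it means among the compounds named here.

Measured compounds:
compound 1 `CCCN(CC[C@H]1CC[C@H](NC(=O)/C=C/c2ccc(F)cc2)CC1)[C@H]1CCc2nc(N)sc2C1`: 1 nM
compound 2 `CCCN(CC[C@H]1CC[C@H](NC(=O)/C=C/c2ccc(OC)cc2)CC1)[C@H]1CCc2nc(N)sc2C1`: 6.7 nM

In an assay on brain for displacement of a labelled ligand from D(3) dopamine receptor (Rattus norvegicus) (a lower number here means a stronger inhibitor, a higher number a weaker inhibitor), compound 1 gives 1 nM, the lowest of the two numbers shown, while compound 2 gives 6.7 nM; the single measured step is a 6.7-fold higher number from compound 1 to compound 2 (0.83 log units; beyond the scatter). Compound 3 `CCCN(CC[C@H]1CC[C@H](NC(=O)c2ccc3ccccc3n2)CC1)[C@H]1CCc2nc(N)sc2C1` differs from compound 1 by quinolin-2-yl in place of 2-(4-fluorophenyl)ethenyl on a carbonyl carbon. That measured step only changed one substituent on the ring, whereas here the whole group is exchanged, so it bears on this change only loosely. A modest weakening is expected. Compound 3 is estimated at 3 nM, with a range from 0.5 nM to 20 nM. This corresponds to an expected step of a 3.0-fold higher number from compound 1 to compound 3 (0.48 log units; beyond the scatter).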

Compound 3, inhibition constant: 1.6 nM
Compound 3: the middle estimate sits 1.9-fold (0.27 log units) above what was measured, within the range that was stated.
By their numbers in this assay, from the lowest: compounds 1 and 3 (each within the scatter of the next); then compound 2.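

In this assay, the change need not stop at a substituent on the ring: replacing the whole 2-(4-fluorophenyl)ethenyl arm on the carbonyl carbon with quinolin-2-yl gives a 1.6-fold higher number from compound 1 to compound 3 (0.20 log units; within the scatter) and so keeps the number within the scatter, even without the double bond outside aromatic rings. Quinolin-2-yl in place of 2-(4-methoxyphenyl)ethenyl gives a 4.2-fold lower number from compound 2 to compound 3 (0.62 log units; beyond the scatter) on the same carbonyl carbon. Nothing available explains either step. Still open, from the compounds shown here alone, is whether the ring nitrogen of quinolin-2-yl matters, which a naphthalen-2-yl group would test. A smaller group, such as plain phenyl, also remains to be compared.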